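The source may hold more compounds than are shown below. What is called first, only, known or untested is meant among the compounds shown, and "the series" means these compounds.

Among the measured compounds shown here, in a functional assay on U-87MG ATCC cells for cytotoxicity against U-87 MG (Homo sapiens), read by MTT assay, with a stated time of 72 h (a higher number here means a weaker inhibitor, a lower number a stronger inhibitor), compound 1 `COc1ncc(-c2ccc3nc(NC(=O)NCCN4CCCC4)nn3c2)cc1NS(=O)(=O)c1ccc(F)cc1` gives 1120 nM, while compound 2 `COc1ncc(-c2ccc3nc(NC(=O)NC4CC4)nn3c2)cc1NS(=O)(=O)c1ccc(F)cc1` gives 540 nM, the lower of the two numbers so far. Compound 3 `COc1ncc(-c2ccc3nc(NC(=O)NCCN(C)C)nn3c2)cc1NS(=O)(=O)c1ccc(F)cc1` is still unmeasured. Its difference from compound 2 is 2-(dimethylamino)ethyl in place of cyclopropyl on an amide-type nitrogen. For the measured compounds named here, one measured step bears on this, a 2.1-fold lower number from compound 1 to compound 2 (0.32 log units; beyond the scatter), a modest change just beyond the scatter, with cyclopropyl in place of 2-(pyrrolidin-1-yl)ethyl on an amide-type nitrogen. The new change runs the opposite way, from cyclopropyl to a substituted ethyl group. Going by that single step, a modest rise of similar size is expected in this assay, though one step is thin support. The expected step is a 1.9-fold higher number from compound 2 to compound 3 (0.27 log units; within the scatter). For compound 3 the estimate is 1000 nM, with an expected range of 450 nM to 2200 nM.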

Compound 3, half-maximal inhibitory concentration: 980 nM
Compound 3: middle estimate off by 1.0-fold (0.01 log units), on the high side; low and high end bracket the measured number.
By their numbers in this assay, from the lowest: compounds 2, 3 and 1 (each within the scatter of the next, the first and the last beyond it).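

In this assay the change to 2-(dimethylamino)ethyl on the amide-type nitrogen reads as a 1.8-fold higher number from compound 2 to compound 3 (0.26 log units; within the scatter), so at this position the replacement of cyclopropyl cannot be told from no change. Exchanging the amine on the saturated chain carbon, dimethylamino in place of pyrrolidin-1-yl, reads as a 1.1-fold lower number from compound 1 to compound 3 (0.06 log units; within the scatter), so these two amines are not separated in this assay. Among the three compounds, only compound 1 and compound 2 stand apart beyond the scatter. No measurement available here accounts for these numbers.

Still open, going by these compounds, is whether a morpholine in place of pyrrolidin-1-yl, or a longer chain carrying dimethylamino, would move the number beyond the scatter. A cyclobutyl group or a carboxylic acid on the same nitrogen is equally untested in the compounds shown.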